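Methyl for Fluoro on a Chloroacetamide Chalcone

A few compounds are considered here, and "the series" means these few. Any claim that something is new, unique, unknown or untested is made for them only; others in the source may bear on it.

Compound 1 `CCCCCCSC(=S)N[C@H]1CCOC1=O` reaches only a limit in a functional assay on MCF7 cells (Homo sapiens) for cytotoxicity, read by MTT assay, with a stated time of 72 h (a lower number here means a stronger inhibitor, a higher number a weaker inhibitor), where it gives > 128000 nM, and this is all that is known of it: the limit of > 128000 nM in this assay, at which 1 of the 2 values shown sits. For the measured compounds named here, compound 2 `O=C(CCl)Nc1ccc(C(=O)/C=C/c2ccc(F)cc2)cc1` is the one compound with a number in this assay, giving 5470 nM. Compound 3 `Cc1ccc(/C=C/C(=O)c2ccc(NC(=O)CCl)cc2)cc1` has not yet been measured there. It differs from compound 2 by methyl in place of fluoro on an aromatic carbon. Going by the values given here, no measured pair shows how such an exchange moves this read-out, so the expected step of a 1.1-fold lower number from compound 2 to compound 3 (0.04 log units; within the scatter) lies within the usual scatter, with no direction favoured. Compound 3 is estimated at 5000 nM, between 1800 nM and 14000 nM.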

Compound 3, half-maximal inhibitory concentration: 9180 nM
For compound 3 the middle estimate is 1.8-fold (0.26 log units) below the measured one; the measured number falls inside the stated range.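

The exchange of 4-fluorophenyl to 4-methylphenyl now has a measured pair, and in this assay it gives a 1.7-fold higher number from compound 2 to compound 3 (0.22 log units; within the scatter). At this position, para to a large group, fluoro and methyl therefore cannot be told apart in this read-out, so this single pair gives the position no direction. No measured property on hand bears on this step. Going by these compounds, it remains open whether an amine or a carboxylic acid on the same aromatic carbon would move the number beyond the scatter. On these data alone, whether the chloroacetamide contributes to the read-out is also open.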